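The source may report more compounds than this note shows. Statements on the series, on what has been measured and on what is new or still open speak of the compounds shown alone.

Of the compounds shown here, two have been tested. Compound 1 `COc1cc(/C=C/C(=O)/C=C/c2cccc3ccccc23)ccc1OCc1cn(CCOc2cc(=O)oc3ccccc23)nn1` gives 20% in a functional assay on PC-3 cells (Homo sapiens) for inhibition, read by sulforhodamine B assay, with a stated time of 48 h, tested at 50 uM (on this read-out lower numbers stand for less inhibition of growth and higher numbers for more inhibition of growth at the one concentration tested), and compound 2 `COc1cc(/C=C/C(=O)/C=C/c2cccs2)ccc1OCc1cn(CCOc2cc(=O)oc3ccccc23)nn1` gives 12%. Among the compounds with values here, compound 2 therefore holds the lower of the two numbers, but the single measured step, a number 8 percentage points lower from compound 1 to compound 2 (within the scatter), lies within the scatter, so the two values cannot be told apart. Compound 3 `COc1cccc(/C=C/C(=O)/C=C/c2ccc(OCc3cn(CCOc4cc(=O)oc5ccccc45)nn3)c(OC)c2)c1` has not yet been measured. It differs from compound 2 in one place: 3-methoxyphenyl in place of thiophen-2-yl on a double-bonded chain carbon bound to a double-bonded chain carbon. Within the data shown here, the only measured step that bears on this change is the swap of one aryl group for another on the same chain carbon, from compound 1 to compound 2, and that step stayed within the scatter. On that basis the step from compound 2 to compound 3 is expected to be small as well, a number 5 percentage points higher from compound 2 to compound 3 (within the scatter), with no direction beyond the scatter. The estimate for compound 3 is 17%, within a range from 4% to 34%.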

Compound 3, percent growth inhibition at one concentration: 13%
Compound 3: middle estimate off by 4 percentage points, on the high side, within the range that was stated.
By their numbers in this assay, from the lowest: compounds 2, 3 and 1 (each within the scatter of the next).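

At the double-bonded chain carbon bound to a double-bonded chain carbon, a third aromatic group now stands beside the first two, and this assay still separates none of them. Placing 3-methoxyphenyl there gives a number 1 percentage points higher from compound 2 to compound 3 (within the scatter) and a number 7 percentage points lower from compound 1 to compound 3 (within the scatter), so neither the change from a five-membered aromatic ring with a hetero atom to a six-membered ring of carbon only, nor the change from naphthalen-1-yl, moves the number beyond the scatter. Nothing available explains why these swaps leave the read-out so little changed.

The compounds shown leave open whether any group at this place can move the number beyond the scatter. A phenyl ring carrying an amine or a carboxylic acid, for example, would test this, as would a saturated chain in place of the aromatic ring.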